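Sulfonyl aryl variation on the benzoxazole-like shared core

The compounds below may be only part of what the source reports. "The series", "measured", "known", "first", "only" and "open" are said of these compounds alone.

Measured so far:
- compound 1 `O=S(=O)(Nc1ccc(-c2nc3cc(NS(=O)(=O)c4ccccc4O)ccc3o2)cc1)c1ccccc1O`: 18000 nM
- compound 2 `O=S(=O)(Nc1ccc2oc(-c3ccccc3)nc2c1)c1cccs1`: 90000 nM
- compound 3 `COc1ccc(Cl)cc1S(=O)(=O)Nc1ccc2oc(-c3ccccc3)nc2c1`: > 100000 nM

In an assay on cells for inhibition of HSP60/HSP10 (Homo sapiens), with a stated time of 60 min (a higher number here means a weaker inhibitor, a lower number a stronger inhibitor), compound 1 gives 18000 nM with two 2-hydroxyphenyl sulfonamide arms on its core. On the shared core of compound 2 and compound 3, compound 2 gives 90000 nM in this assay. For compound 3 this assay reports only a limit, > 100000 nM, so compound 3 stands at the weak end of the numbers shown without a fixed value (the limit of > 100000 nM in this assay, at which 1 of the 3 values shown sits). For the measured compounds named here, the one measured step, an at least 1.1-fold higher number from compound 2 to compound 3 (0.04 log units; that floor lies within the scatter), is itself only a floor.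

Compound 4 `O=S(=O)(Nc1ccc2oc(-c3ccccc3)nc2c1)c1ccccc1O` differs from compound 3 by 2-hydroxyphenyl in place of 5-chloro-2-methoxyphenyl on a sulfonyl sulfur. Going by the values given here, no measured step changes a sulfonyl aryl group to 2-hydroxyphenyl on this core; the only guide is that compound 1, carrying two such groups, sits below compound 2 and compound 3 in number. The change is therefore expected to give a lower number, an at least 2.0-fold lower number from compound 3 to compound 4 (0.30 log units; that floor lies within the scatter), though this rests on a limit. Compound 4 is estimated at 50000 nM, between 15000 nM and 150000 nM.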

Compound 4, half-maximal inhibitory concentration: 85000 nM
Compound 4: middle estimate off by 1.7-fold (0.23 log units), on the low side, within the range that was stated.
By their numbers in this assay, from the lowest: compound 1; then compounds 4 and 2 (each within the scatter of the next). At a limit, above all of these: compound 3.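

In this assay, 2-hydroxyphenyl on the sulfonyl sulfur does not separate from thiophen-2-yl on the shared core: a 1.1-fold lower number from compound 2 to compound 4 (0.02 log units; within the scatter). Against 5-chloro-2-methoxyphenyl the change can be read only as a floor, an at least 1.1-fold lower number from compound 3 to compound 4 (0.07 log units; that floor lies within the scatter), because one end of the step is a limit: the limit of > 100000 nM in this assay, at which 1 of the 4 values shown sits. The one step beyond the scatter lies elsewhere, a 4.7-fold higher number from compound 1 to compound 4 (0.67 log units; beyond the scatter), with hydrogen in place of ((2-hydroxyphenyl)sulfonyl)amino on an aromatic carbon, so in this set the lower number goes with that second arm and not with the 2-hydroxyphenyl group alone.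

Open, on these data alone, is whether a smaller group on that aromatic carbon, such as an amine, would keep any of this step. Also open, as far as these compounds go, is whether a carboxylic acid on the aryl group at the sulfonyl sulfur would move the number at all.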